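The source may report more compounds than this note shows. Statements on the series, on what has been measured and on what is new or still open speak of the compounds shown alone.

Compound 3, with the structure `Cc1cc(-c2ccc(N3C(=O)C(O)=C(C(=O)C(C)(C)C)C3c3ccccc3OCCO)cc2)on1`, has in an ADME assay on the whole organism (Rattus norvegicus) for pharmacokinetics (a lower number here means slower removal, a higher number faster removal of the compound), only the entry "not determined" (no result reported): for compound 3 this assay gives no single number, so it stands nowhere on the measured scale. Two other compounds share its core. Compound 1, with the structure `O=C(C1=C(O)C(=O)N(c2ccc(-c3ccon3)cc2)C1C1CCCCC1)c1ccc(CO)cc1`, gives in this assay a reading of 3.8 mL/min/kg. Compound 2, with the structure `COc1ccc(C(=O)C2=C(O)C(=O)N(c3ccc(-c4ccon4)cc3)C2c2ccccc2OCCO)cc1`, gives in this assay a reading of 67.6 mL/min/kg. These two readings lie far apart, but neither compound differs from compound 3 in only one place, so they mark out only the span within which this series has been seen so far.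

Compound 4, with the structure `CC(C)(C)C(=O)C1=C(O)C(=O)N(c2ccc(-c3ccsc3)cc2)C1c1ccccc1OCCO`, differs from compound 3 in one place: thiophen-3-yl in place of 3-methyl-1,2-oxazol-5-yl on an aromatic carbon. From the compounds shown here alone, with no reading for compound 3, this step has no measured starting point, and no direction in this assay can be read from the data for the change of thiophen-3-yl in place of 3-methyl-1,2-oxazol-5-yl; a step of any size, or none beyond the scatter, remains open. Compound 4 shares its two-carbon hydroxy-ether side group with compound 2, whose reading is 67.6 mL/min/kg, and on that basis the reading for compound 4 is expected at 35 mL/min/kg, within a range from 8 mL/min/kg to 110 mL/min/kg.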

Compound 4, clearance in the Rattus norvegicus assay: 0.5 mL/min/kg
The estimate for compound 4 lay 70-fold (1.85 log units) above the measured number; the measured number lies below the stated range.
By their numbers in the Rattus norvegicus assay, from the lowest: compound 4; then compound 1; then compound 2.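

In a physicochemical assay for solubility, in phosphate buffer, at pH 6.8 (a higher number here means a more soluble compound, a lower number a less soluble compound), compound 3 gives > 50000 nM, which is a limit and not a number. In the physicochemical assay compound 4 gives > 50000 nM, likewise a limit. No step between compound 3 and compound 4 can be read from these entries, because both stand at the same limit: the limit of > 50000 nM in the physicochemical assay, at which 2 of the 2 values shown sit.

The compounds shown leave open how far either compound lies past that limit in the physicochemical assay, and where compound 3 stands in the Rattus norvegicus assay relative to compound 4.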